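The source may hold more compounds than are shown below. What is called first, only, known or untested is meant among the compounds shown, and "the series" means these compounds.

Measured so far in a functional assay on DU-145 cells (Homo sapiens) for inhibition, read by trypan blue exclusion, with a stated time of 96 h; a lower number here means a stronger inhibitor of growth, a higher number a weaker inhibitor of growth:
compound 1, `O=C(/C(=C\c1ccccc1OCc1ccccc1)SCc1ccc(F)cc1)c1ccc(Cl)cc1`: 1000 nM
compound 2, `O=C(/C(=C\c1ccccc1OCc1ccccc1)Sc1ccc(F)cc1)c1ccc(Cl)cc1`: 1000 nM
compound 3, `Cc1ccc(/C=C(/Sc2ccc(F)cc2)C(=O)c2ccc(Cl)cc2)s1`: 25000 nM

In this assay compound 2 gives 1000 nM and compound 1 gives 1000 nM. The change between them is 4-fluorobenzyl in place of 4-fluorophenyl on a sulfur, and it made the step of no change at the digits printed from compound 2 to compound 1 (within the scatter). Compound 3 gives 25000 nM in this assay; how its core differs from the core of compound 2 is not broken down here. Compound 4, `Cc1ccc(/C=C(/SCc2ccc(F)cc2)C(=O)c2ccc(Cl)cc2)s1`, is not yet measured. It differs from compound 3 by 4-fluorobenzyl in place of 4-fluorophenyl on a sulfur, the same change that led from compound 2 to compound 1, at the same place. The step from compound 3 to compound 4 in this assay is therefore expected to be no change at the digits printed from compound 3 to compound 4 (within the scatter), resting on the single earlier case, where the step was no change at the digits printed from compound 2 to compound 1 (within the scatter). Compound 4 is expected to give about 25000 nM in this assay, estimated between 8000 nM and 70000 nM.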

Compound 4, concentration for 50% growth inhibition: > 100000 nM
Compound 4 was reported as a limit (the forecaster's own chance of this, stated with the estimate: 10%); at least 4.0-fold (0.60 log units) between middle value and limit.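

In this assay compound 4 gives > 100000 nM, which is a limit of the assay and not a number. Read as a limit, the change of 4-fluorophenyl to 4-fluorobenzyl on a sulfur gives an at least 4.0-fold higher number from compound 3 to compound 4 (0.60 log units; beyond the scatter), so its outcome did not carry over from one core to the other: the same change on two cores in this assay, no change at the digits printed (within the scatter) from compound 2 to compound 1 and an at least 4.0-fold higher number (0.60 log units; beyond the scatter) from compound 3 to compound 4, at least 4.0-fold (0.60 log units) apart, beyond the scatter of two such steps With one pair on each core, this does not show the true size of the second step, nor which difference between the cores goes with the gap.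

The compounds shown leave open how a longer chain on the sulfur, such as 2-(4-fluorophenyl)ethyl, would behave on either core. They also leave open whether an amine or a carboxylic acid in place of the fluorinated ring would follow either step.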